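A Chloro Shift on the Phenoxy Ring

The source may report more compounds than this note shows. Statements on the series, on what has been measured and on what is new or still open speak of the compounds shown alone.

Compound 1 `O=C(Oc1ccc([N+](=O)[O-])cc1)N1CCN(S(=O)(=O)c2ccc(C3CCCCC3)cc2)CC1` gives 333 nM in an assay on isolated protein for inhibition of Fatty-acid amide hydrolase 1 (Homo sapiens), read by fluorescence; on this read-out lower numbers stand for stronger inhibition and higher numbers for weaker inhibition.
Compound 2 `O=C(Oc1ccc([N+](=O)[O-])cc1)N1CCN(S(=O)(=O)c2ccc(Oc3ccccc3)cc2)CC1` gives 322 nM.
Compound 3 `O=C(Oc1ccc([N+](=O)[O-])cc1)N1CCN(S(=O)(=O)c2ccc(Oc3cccc(Cl)c3)cc2)CC1` gives 380 nM.

On these numbers compound 2 differs from compound 1 and from compound 3 only within the scatter, as a 1.0-fold lower number from compound 1 to compound 2 (0.01 log units; within the scatter) and a 1.2-fold higher number from compound 2 to compound 3 (0.07 log units; within the scatter) show. Compound 4 `O=C(Oc1ccc([N+](=O)[O-])cc1)N1CCN(S(=O)(=O)c2ccc(Oc3ccccc3Cl)cc2)CC1` carries chloro in place of hydrogen on an aromatic carbon. The step that bears on this is a 1.2-fold higher number from compound 2 to compound 3 (0.07 log units; within the scatter), where the same group enters the phenoxy ring at another position and leaves the number within the scatter. The exchange of cyclohexyl for phenoxy, a 1.0-fold lower number from compound 1 to compound 2 (0.01 log units; within the scatter), also moved nothing beyond the scatter. Compound 4 is therefore expected to give a step of a 1.1-fold higher number from compound 2 to compound 4 (0.02 log units; within the scatter), with no change beyond the scatter. The estimate for compound 4 is 340 nM, between 170 nM and 680 nM.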

Compound 4, half-maximal inhibitory concentration: 1150 nM
Beside the measured number, compound 4's estimate is 3.4-fold (0.53 log units) below it, and the stated range ends below it.
By their numbers in this assay, from the lowest: compounds 2, 1 and 3 (each within the scatter of the next); then compound 4.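

In this assay, going by these compounds alone, chloro on the phenoxy ring does not always leave the number within the scatter: as 2-chlorophenoxy it gives a 3.6-fold higher number from compound 2 to compound 4 (0.55 log units; beyond the scatter) as the first step in the set beyond the scatter. The place of the chloro counts, since 2-chlorophenyl in place of 3-chlorophenyl gives a 3.0-fold higher number from compound 3 to compound 4 (0.48 log units; beyond the scatter) and 2-chlorophenoxy in place of cyclohexyl gives a 3.5-fold higher number from compound 1 to compound 4 (0.54 log units; beyond the scatter) as well. Nothing shown gives a reason for this loss. From the compounds shown here alone, whether fluoro, methoxy or an amine on that same aromatic carbon would raise the number as chloro does remains open.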